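The compounds below may be only part of what the source reports. "The series", "measured", "known", "first", "only" and "open" are said of these compounds alone.

Three measured compounds:
Compound 1 `CCOC(=O)[C@H](C)NC(=O)/C=C/c1ccc(O)c(O)c1` gives in a functional assay, read by spectrophotometry, with a stated time of 30 min (a higher number here means a weaker inhibitor, a lower number a stronger inhibitor), 29700 nM.
Compound 2 `CCOC(=O)CNC(=O)/C=C/c1ccc(O)c(O)c1` gives in this assay 18600 nM.
Compound 3 `CCOC(=O)[C@H](CC(C)C)NC(=O)/C=C/c1ccc(O)c(O)c1` gives in this assay 28600 nM.

Compound 1 carries the highest of the three numbers, but its steps to the others, a 1.6-fold lower number from compound 1 to compound 2 (0.20 log units; within the scatter) and a 1.0-fold lower number from compound 1 to compound 3 (0.02 log units; within the scatter), lie within the scatter, as does a 1.5-fold higher number from compound 2 to compound 3 (0.19 log units; within the scatter); the three values cannot be ordered. Compound 4 `CCOC(=O)[C@H](C)NC(=O)/C=C/c1ccc(O)c(OC)c1` differs from compound 1 by methyl in place of hydrogen on an oxygen on an aromatic ring. None of the three measured steps touches this oxygen; each of them alters only the saturated chain carbon bound to the amide-type nitrogen. Among the compounds with values here, no measured step therefore bears on the change in this assay, and its size is unknown. Compound 4 is expected to give 50000 nM, estimated between 15000 nM and 150000 nM. The expected step is a 1.7-fold higher number from compound 1 to compound 4 (0.23 log units; within the scatter).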

Compound 4, half-maximal inhibitory concentration: 46400 nM
The estimate for compound 4 lay 1.1-fold (0.03 log units) above the measured number, and the stated range covers the measured number.
By their numbers in this assay, from the lowest: compounds 2, 3, 1 and 4 (each within the scatter of the next, the first and the last beyond it).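

Unlike the earlier steps, which all altered the saturated chain carbon, this one reaches the core, and hydroxy to methoxy at this oxygen on an aromatic ring gives a 1.6-fold higher number from compound 1 to compound 4 (0.19 log units; within the scatter) in this assay. For this pair, then, methyl can stand in place of the hydrogen on this oxygen without a difference beyond the scatter. No supporting measurement offers an explanation for this result. Still open, going by these compounds, is whether ethyl or benzyl on this oxygen would read the same, and whether methyl on the other ring hydroxy would.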